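The source may hold more compounds than are shown below. What is called first, only, known or untested is meant among the compounds shown, and "the series" means these compounds.

In a functional assay on SK-OV-3 cells (Homo sapiens) for cytotoxicity, read by MTT assay, with a stated time of 3 days (on this read-out lower numbers stand for stronger inhibition and higher numbers for weaker inhibition), compound 1 `N#Cc1c(O)nc(SCc2nc3ccccc3[nH]2)nc1-c1ccccc1` gives 2.55 nM and compound 2 `N#Cc1c(Cl)nc(SCc2nc3ccccc3[nH]2)nc1-c1ccccc1` gives 3.37 nM on the same core. Compound 3 `CCNc1nc(SCc2nc3ccccc3[nH]2)nc(-c2ccccc2)c1C#N` gives 7.35 nM as the highest number of the three. Compound 4 `N#Cc1c(Nc2ccccn2)nc(SCc2nc3ccccc3[nH]2)nc1-c1ccccc1` has pyridin-2-yl in place of ethyl on a nitrogen on an aromatic ring, a change counted as pyridin-2-yl in place of ethyl on a nitrogen on an aromatic ring here. Within the data shown here, no measured step makes this swap. The nearest ones exchange the whole group: ethylamino in place of hydroxy gave a 2.9-fold higher number from compound 1 to compound 3 (0.46 log units; beyond the scatter) and ethylamino in place of chloro gave a 2.2-fold higher number from compound 2 to compound 3 (0.34 log units; beyond the scatter) as well, both modest. Neither sets a direction here, so the expected change stays within the scatter, estimated as a 1.2-fold lower number from compound 3 to compound 4 (0.09 log units; within the scatter) at this stage. Compound 4 is expected at 6 nM with an estimated range from 2 nM to 20 nM for now.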

Compound 4, half-maximal inhibitory concentration: 5.81 nM
Beside the measured number, compound 4's estimate is 1.0-fold (0.01 log units) above it; the range from low to high includes it.
By their numbers in this assay, from the lowest: compounds 1, 2, 4 and 3 (each within the scatter of the next, the first and the last beyond it).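

Replacing ethyl with pyridin-2-yl on the nitrogen, which adds an aromatic ring, leaves the number within the scatter (a 1.3-fold lower number from compound 3 to compound 4 (0.10 log units; within the scatter)). The (pyridin-2-yl)amino group also stays within the scatter when it replaces chloro (a 1.7-fold higher number from compound 2 to compound 4 (0.24 log units; within the scatter)), but it lies beyond the scatter when it replaces hydroxy (a 2.3-fold higher number from compound 1 to compound 4 (0.36 log units; beyond the scatter)). No other measurement bears on why the numbers fall this way.

Still open, as far as these compounds go, is how a longer chain such as butyl, or a plain phenyl, would read on that nitrogen. From the compounds shown here alone, the effect of a carboxylic acid on the aromatic ring of pyridin-2-yl is also open.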